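A few compounds are considered here, and "the series" means these few. Any claim that something is new, unique, unknown or untested is made for them only; others in the source may bear on it.

Working notes on the series. Within the data shown here, in a functional assay on DU-145 cells (Homo sapiens) for inhibition, read by MTT assay, with a stated time of 72 h (on this read-out lower numbers stand for stronger inhibition and higher numbers for weaker inhibition), compound 1 `O=C(O)CCCCCCC(=O)Nc1ccc(C2=C(c3ccc(O)cc3)C3CC(S(=O)(=O)Oc4cccc5ccccc45)C2O3)cc1` gives 48600 nM, the higher of the two numbers so far. Compound 2 `O=C(CCCCCCC(=O)Nc1ccc(C2=C(c3ccc(O)cc3)C3CC(S(=O)(=O)Oc4cccc5ccccc45)C2O3)cc1)NO`, with hydroxyamino in place of hydroxy on a carbonyl carbon, gives 8570 nM. Among the measured compounds shown here, that change is the only measured step, a 5.7-fold lower number from compound 1 to compound 2 (0.75 log units; beyond the scatter), a modest one beyond the scatter.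

Compound 3 `O=C(O)CCCCCCC(=O)Nc1ccc(C2=C(c3ccc(O)cc3)C3CC(S(=O)(=O)Oc4ccc5ccccc5c4)C2O3)cc1` keeps the carbonyl hydroxy of compound 1 and differs elsewhere: naphthalen-2-yl in place of naphthalen-1-yl on an oxygen. This places naphthalen-2-yl in place of naphthalen-1-yl on an oxygen whose other neighbour is the sulfonyl sulfur. The measured step concerns a different place, so it gives neither a size nor a direction for this change. It shows only what one single change has done so far in this assay. For the measured compounds named here, with no measured pair that varies this group, no step beyond the scatter is expected, though the uncertainty is wide. The expected step is a 1.2-fold lower number from compound 1 to compound 3 (0.06 log units; within the scatter), which is an estimate and carries no firm direction. For compound 3 the estimated value is 42000 nM, with an expected range from 15000 nM to 100000 nM.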

Compound 3, half-maximal inhibitory concentration: 58300 nM
The estimate for compound 3 lay 1.4-fold (0.14 log units) below the measured number; low and high end bracket the measured number.
By their numbers in this assay, from the lowest: compound 2; then compounds 1 and 3 (each within the scatter of the next).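

In this assay, the change from naphthalen-1-yl to naphthalen-2-yl on the oxygen whose other neighbour is the sulfonyl sulfur gives a 1.2-fold higher number from compound 1 to compound 3 (0.08 log units; within the scatter). Among these compounds, this is the first measured step at this position, and it shows that, with the carbonyl hydroxy of compound 1 kept, this exchange between two groups with the same atoms does not separate the two compounds in this assay, so the step gives no preference for either naphthalenyl group. Nothing at hand offers a measured explanation for this result.

The compounds shown leave open whether the same exchange would also stay within the scatter with hydroxyamino on the carbonyl carbon, as in compound 2, since only the carbonyl hydroxy pair has been compared at this position. They also leave open how a group of a different kind on the same oxygen, such as a phenyl ring or a simple methyl group, would read in this assay, since the two groups seen here differ only in how they are joined.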